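Series notes: trimethoxyphenyl on the five-membered ring of compound 1

This account rests on a few compounds, and the source may have more. Where it says the series, first, only, none or still open, it means among the compounds named here.

Compound 1 `COc1ccc(-c2cn(-c3cccc(C(=O)/C=C/c4cc(OC)c(OC)c(OC)c4)c3)c(=O)[nH]2)cc1` gives 920 nM in a functional assay on RPMI8266 cells (Homo sapiens) for inhibition (on this read-out higher numbers stand for weaker inhibition of growth and lower numbers for stronger inhibition of growth), the lowest of the three numbers shown. Compound 2 `COc1ccc(-c2cn(-c3cccc(C(=O)/C=C/c4ccc(O)c(OC)c4)c3)c(=O)[nH]2)cc1` gives 1350 nM, and compound 3 `O=C(/C=C/c1cccc(O)c1)c1cccc(-n2cc(-c3ccccc3)[nH]c2=O)c1` gives 2150 nM. The one single-site step shown, a 1.5-fold higher number from compound 1 to compound 2 (0.17 log units; within the scatter), concerns the chain side only.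

Compound 4 `COc1cc(/C=C/C(=O)c2cccc(-n3cc(-c4cc(OC)c(OC)c(OC)c4)[nH]c3=O)c2)cc(OC)c1OC` differs from compound 1 at the other end: 3,4,5-trimethoxyphenyl in place of 4-methoxyphenyl on an aromatic carbon. Within the data shown here, no measured step touches this position, so the step from compound 1 to compound 4 has no direct precedent; the chain-side step stayed within the scatter, and the same is expected here. Compound 4 is therefore estimated at 900 nM, within 400 nM to 2000 nM, an expected step of a 1.0-fold lower number from compound 1 to compound 4 (0.01 log units; within the scatter).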

Compound 4, concentration for 50% growth inhibition: 230 nM
Compound 4: middle estimate off by 3.9-fold (0.59 log units), on the high side; measured number below the stated range.
By their numbers in this assay, from the lowest: compound 4; then compounds 1, 2 and 3 (each within the scatter of the next, the first and the last beyond it).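

Among these compounds, at the aromatic carbon of the five-membered aromatic ring, this change gives the first step beyond the scatter in this assay: a 4.0-fold lower number from compound 1 to compound 4 (0.60 log units; beyond the scatter). The chain-side step, a 1.5-fold higher number from compound 1 to compound 2 (0.17 log units; within the scatter), stayed within the scatter, so this position responds to a change of aryl group where that step did not. No available data account for the gain. On these data alone, it remains open whether the step persists with the 4-hydroxy-3-methoxyphenyl chain group of compound 2. Also open, as far as these compounds go, is how a pyridyl group or a carboxylic acid-bearing phenyl would behave at this position.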